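The source may report more compounds than this note shows. Statements on the series, on what has been measured and on what is new or still open speak of the compounds shown alone.

Values so far in an ADME assay on HepG2 cells (Homo sapiens) for cytotoxicity, read by fluorescence and resazurin assay, with a stated time of 24 h; on this read-out higher numbers stand for lower toxicity in this test and lower numbers for higher toxicity in this test
compound 1 `O=S1(=O)C=C(Sc2nnc(-c3cccnc3)o2)c2ccccc21` gives 14000 nM
compound 2 `Nc1ccc(-c2nnc(SC3=CS(=O)(=O)c4ccccc43)o2)cc1` gives 24000 nM
compound 3 `O=S1(=O)C=C(Sc2nnc(-c3ccccc3Cl)o2)c2ccccc21` gives 25000 nM

Compound 3 cannot be separated from the other two compounds on these numbers. Both a 1.0-fold higher number from compound 2 to compound 3 (0.02 log units; within the scatter) and a 1.8-fold higher number from compound 1 to compound 3 (0.25 log units; within the scatter) stay within the scatter.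

Compound 4 `COc1ccc(-c2nnc(SC3=CS(=O)(=O)c4ccccc43)o2)cc1` is not yet measured. It differs from compound 3 by 4-methoxyphenyl in place of 2-chlorophenyl on an aromatic carbon of the five-membered aromatic ring with 2 nitrogen and 1 oxygen (4-methoxyphenyl in place of 2-chlorophenyl on an aromatic carbon).

All three measured steps involve exchanges at this same place. The closest guide is a 1.0-fold higher number from compound 2 to compound 3 (0.02 log units; within the scatter) and it involves the leaving 2-chlorophenyl and a 4-substituted phenyl. The other two, a 1.7-fold higher number from compound 1 to compound 2 (0.23 log units; within the scatter) and a 1.8-fold higher number from compound 1 to compound 3 (0.25 log units; within the scatter) also lie within the scatter. For the measured compounds named here, no measured compound carries 4-methoxyphenyl, so this is an extrapolation from three close values and not a direct reading.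

No direction can be drawn from these steps, and no change beyond the scatter is expected in this assay for this exchange. The expected result is a 1.2-fold lower number from compound 3 to compound 4 (0.08 log units; within the scatter) and this estimate stays within the scatter. For compound 4 the estimated value is 21000 nM with an expected range from 10000 nM to 45000 nM in this read-out.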

Compound 4, half-maximal cytotoxic concentration: 22000 nM
For compound 4 the middle estimate is 1.0-fold (0.02 log units) below the measured one; the range from low to high includes it.
By their numbers in this assay, from the lowest: compounds 1, 4, 2 and 3 (each within the scatter of the next).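

Working notes on the aryl position, the aromatic carbon of the five-membered ring next to the ring nitrogen and the ring oxygen. In this assay the entry of 4-methoxyphenyl gives a 1.1-fold lower number from compound 3 to compound 4 (0.06 log units; within the scatter) and a 1.6-fold higher number from compound 1 to compound 4 (0.20 log units; within the scatter) as its steps from the 2-chlorophenyl and pyridin-3-yl compounds, and neither step separates the new compound from them. For the compounds shown here, the pair of compound 2 and compound 4 adds the first exchange confined to the group carried on a 4-substituted phenyl, methoxy in place of amino, and a 1.1-fold lower number from compound 2 to compound 4 (0.04 log units; within the scatter) also lies within the scatter. Four different aromatic groups at this carbon now give numbers that cannot be told apart in this read-out, and no measurement at hand offers an explanation for that.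

From the compounds shown here alone, all four compounds carry a six-membered aromatic ring at this carbon, so it remains open whether a piperidine or a longer alkyl chain in its place would give a step beyond the scatter. Equally open, going by these compounds, is the effect of a carboxylic acid on the phenyl ring.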